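Amide replacement and cytotoxicity toward a human monocytic line

The source may report more compounds than this note shows. Statements on the series, on what has been measured and on what is new or still open speak of the compounds shown alone.

Compound 1 `COc1ccc(-c2cnc(NC(=O)C3CCOCC3)n2C)cc1`: in a toxicity assay on THP-1 cells (Homo sapiens) for inhibition (on this read-out lower numbers stand for higher toxicity in this test and higher numbers for lower toxicity in this test), compound 1 reaches only the assay limit, > 100000 nM.
Compound 2 `COc1ccc(-c2cnc(NC(=O)c3ccc(O)cc3)n2C)cc1`: compound 2 also stops at the limit, > 100000 nM.
Compound 3 `COc1ccc(-c2cnc(NC(=O)c3ccc(C#N)cc3)n2C)cc1`: compound 3 likewise shows only the limit, > 100000 nM.

Compound 3 therefore stands where every measured value sits, at the limit (the limit of > 100000 nM in this assay, at which 3 of the 3 values shown sit). The steps a step that the two limits leave unreadable from compound 1 to compound 2, a step that the two limits leave unreadable from compound 1 to compound 3 and a step that the two limits leave unreadable from compound 2 to compound 3 cannot be sized, since both ends of each are limits. Compound 4 `COc1ccc(-c2cnc(NC(=O)c3ccccc3Cl)n2C)cc1` differs from compound 3 by 2-chlorophenyl in place of 4-cyanophenyl on a carbonyl carbon. Among the measured compounds shown here, no measured step bears readably on this change, and the three values at the limit give no direction. Compound 4 is expected to remain at or near that limit, with the step that the limit leaves unreadable from compound 3 to compound 4 expected to stay within scatter. The estimate for compound 4 is 150000 nM, ranging from 50000 nM to 500000 nM.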

Compound 4, half-maximal cytotoxic concentration: > 50000 nM
Compound 4 ended at the assay's limit (the forecaster's own chance of this, stated with the estimate: 85%); the middle value does not contradict the limit.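

Compound 4 reaches only an assay limit, as do compound 1, compound 2 and compound 3, so none of the steps to compound 4 can be read. The compounds shown leave open whether any of these groups on the carbonyl carbon alters the result in this assay.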